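Thiophen-2-yl in Place of Bromo: Expected Inhibition

The source may hold more compounds than are shown below. What is called first, only, known or untested is meant among the compounds shown, and "the series" means these compounds.

Measured so far:
compound 1, `Brc1cn2ccnc2c(-c2ccc3ncn(C4CCCCC4)c3c2)n1`: 6.47% in a functional assay on SN12C cells (Homo sapiens) for inhibition, read by sulforhodamine B assay, with a stated time of 48 h, tested at 10 uM; a higher number here means more inhibition at the concentration tested (going by the name of the read-out), a lower number less inhibition
compound 2, `CC(=O)c1ccc(-c2cn3ccnc3c(-c3ccc4ncn(C5CCCCC5)c4c3)n2)cc1`: 6.33%
compound 3, `COc1ccccc1-c1cn2ccnc2c(-c2ccc3ncn(C4CCCCC4)c3c2)n1`: 7.73%

Compound 1 stands second highest of these three numbers. Its nearest neighbour is compound 2, with a number 0.1 percentage points lower from compound 1 to compound 2 (within the scatter); its furthest is compound 3, with a number 1.3 percentage points higher from compound 1 to compound 3 (within the scatter). Compound 2 and compound 3 are themselves separated by a number 1.4 percentage points higher from compound 2 to compound 3 (within the scatter). All three steps lie within the scatter, so the three measured compounds cannot be told apart in this assay.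

Compound 4, `c1csc(-c2cn3ccnc3c(-c3ccc4ncn(C5CCCCC5)c4c3)n2)c1`, is not yet measured. Relative to compound 1 the change is thiophen-2-yl in place of bromo on an aromatic carbon.

Within the data shown here, the steps that bear on this change are those from compound 1 to compound 2 and from compound 1 to compound 3, where bromo is likewise replaced by an aromatic ring; both were within the scatter. Compound 4 is therefore expected to show no step beyond the scatter, a number 0.5 percentage points higher from compound 1 to compound 4 (within the scatter). For compound 4 the estimate is 7%, with a range from -2% to 18%.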

Compound 4, a percentage reported as inhibition, at one concentration (the size of the read-out at that concentration, not a potency): 2.84%
Estimate against measurement, compound 4: 4.2 percentage points above; measured number inside the range.
By their numbers in this assay, from the lowest: compounds 4, 2, 1 and 3 (each within the scatter of the next).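

Thiophen-2-yl adds a five-membered aromatic ring with a hetero atom to the groups tried on this aromatic carbon, and in this assay the step of a number 3.6 percentage points lower from compound 1 to compound 4 (within the scatter) stands with a number 4.9 percentage points lower from compound 3 to compound 4 (within the scatter) and a number 3.5 percentage points lower from compound 2 to compound 4 (within the scatter) as steps that do not separate the compounds. This position has therefore now carried bromo and three different aromatic rings, and no step among these four compounds lies beyond the scatter. Nothing available here explains these numbers.

The compounds shown leave open whether a group of another kind on this carbon, such as an amine, a carboxylic acid or a longer alkyl chain, would give a step beyond the scatter. On these data alone, all four also share the rest of the structure, so the effect of a change elsewhere on the core remains open.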